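From ethoxy to methoxy: compound 3 to compound 4

This account rests on a few compounds, and the source may have more. Where it says the series, first, only, none or still open, it means among the compounds named here.

Of the compounds shown here, three sharing one core have been read in a functional assay on PC-12 cells (Rattus norvegicus) for inhibition, read by sulforhodamine B assay; on this read-out lower numbers stand for stronger inhibition and higher numbers for weaker inhibition. Going by the values given here, compound 1 `O=C1NC(=O)C(Cc2ccc(OCC3CCCC3)cc2)S1` gives 25000 nM, the only true number in the set. Compound 2 `O=C1NC(=O)C(Cc2ccc(OCC3CC3)cc2)S1` gives > 100000 nM, which is a limit. Compound 3 `CCOc1ccc(CC2SC(=O)NC2=O)cc1` gives > 100000 nM, which is also a limit. Compound 3 therefore has no number of its own, only a place on the high-number side of compound 1.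

Compound 4 `COc1ccc(CC2SC(=O)NC2=O)cc1` differs from compound 3 by hydrogen in place of methyl on a saturated chain carbon bound to an oxygen on an aromatic ring. This puts hydrogen in place of methyl on a saturated chain carbon bound to an oxygen on an aromatic ring, turning ethoxy to methoxy.

Three measured steps fall at this same place. Two are readable: an at least 4.0-fold higher number from compound 1 to compound 2 (0.60 log units; beyond the scatter) and an at least 4.0-fold higher number from compound 1 to compound 3 (0.60 log units; beyond the scatter). Both are only bounded, and both run towards higher numbers as cyclopentyl is replaced by a smaller group. The third, a step that the two limits leave unreadable from compound 2 to compound 3, gives no size.

No recovery of a measurable value is expected in this assay, and any change would most likely run towards higher numbers. The expected step is a step that the limit leaves unreadable from compound 3 to compound 4, and it is not expected to be readable beyond the scatter. For compound 4 the estimated value is 120000 nM, with an expected range of 50000 nM to 300000 nM, most likely reported only as a limit.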

Compound 4, half-maximal inhibitory concentration: > 100000 nM
Compound 4 gave a limit, no number (the forecaster's own chance of this, stated with the estimate: 85%); the middle value lies beyond the limit too.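

In this assay, going by these compounds alone, taking the methyl off the ethoxy group brings back no measurable value, so the cyclopentyl group of compound 1 remains the only group at this place with a true number, and the one readable step added here is an at least 4.0-fold higher number from compound 1 to compound 4 (0.60 log units; beyond the scatter). The steps from compound 3 to compound 4 and from compound 2 to compound 4 cannot be read, so the three compounds with the smaller groups stay unranked against one another, and hydrogen in place of methyl has no size that can be stated. The small end of this position therefore gives no gradation in this assay, since these three compounds all sit on one limit: the limit of > 100000 nM in this assay, at which 3 of the 4 values shown sit.

Within the data shown here, with compound 1 as the only true number, it remains open whether lower numbers would follow from a larger ring at this place, such as cyclohexyl or phenyl, or from a longer chain. On these data alone, it is equally open how an amine or a carboxylic acid at the end of that chain would read on the same scale.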